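The source may hold more compounds than are shown below. What is called first, only, known or untested is meant among the compounds shown, and "the series" means these compounds.

Compound 1: `Cc1ccc(-c2nn(-c3ccc(F)cc3F)cc2CNCCN2CCN(C)CC2)cc1`
Compound 2: `CN1CCN(CCCNCc2cn(-c3ccc([N+](=O)[O-])cc3)nc2-c2ccc(C(F)(F)F)cc2)CC1`

Of the compounds shown here, two have been measured in an ADME assay on Huh-7 cells (Homo sapiens) for cytotoxicity; on this read-out lower numbers stand for higher toxicity in this test and higher numbers for lower toxicity in this test. In this assay compound 1 gives > 20000 nM, which is a limit of the test rather than a number. Compound 1 therefore stands at the limit of > 20000 nM in this assay, at which 1 of the 2 values shown sits. In this assay compound 2 gives 4900 nM. Compound 3, `COC(=O)c1ccc(-c2nn(-c3ccc(F)cc3F)cc2CNCCN2CCN(C)CC2)cc1`, has not been measured yet; it differs from compound 1 in one place: methoxycarbonyl in place of methyl on an aromatic carbon. For the measured compounds named here, no measured pair of compounds shares this change, so no step for it is known. The change exchanges one uncharged group for another at a single aromatic carbon, and compound 1 is known only as a limit, so the step from compound 1 to compound 3 is expected to be about a step that the limit leaves unreadable from compound 1 to compound 3, which is no more than the usual scatter. Compound 3 is expected to give about 25000 nM in this assay, most likely between 8000 nM and 60000 nM, and it may again be reported only as a limit.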

Compound 3, half-maximal cytotoxic concentration: > 20000 nM
Compound 3 gave a limit, no number (the forecaster's own chance of this, stated with the estimate: 65%); the middle value lies beyond the limit too.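

In this assay, for the compounds shown here, compound 1 and compound 3 each give only a limit, not a number, so no step between them can be read: the limit of > 20000 nM in this assay, at which 2 of the 3 values shown sit. The compounds shown leave open whether methoxycarbonyl in place of methyl changes this read-out at all, and by how much.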